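The source may hold more compounds than are shown below. What is called first, only, known or untested is meant among the compounds shown, and "the series" means these compounds.

Compound 2, `COc1cccc(CSc2nnc(-c3ccc4c(c3)OCCO4)n2-c2ccccc2)c1`, is a close relative of compound 1, `O=[N+]([O-])c1ccccc1CSc1nnc(-c2ccc3c(c2)OCCO3)n1-c1ccccc1`. In a functional assay on BGC-823 cells (Homo sapiens) for antiproliferative activity, read by MTT assay, with a stated time of 24 h (a higher number here means a weaker inhibitor, a lower number a stronger inhibitor), compound 1 gives 26500 nM. In this assay compound 2 gives only a limit of the assay, > 100000 nM. For the measured compounds named here, compound 2 thus stands at the weak edge of what the assay can report, as the limit of > 100000 nM in this assay, at which 1 of the 2 values shown sits, records; the one step that reaches it, an at least 3.7-fold higher number from compound 1 to compound 2 (0.57 log units; beyond the scatter), can be read only as a lower bound on its size.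

Compound 3, `Fc1cccc(F)c1CSc1nnc(-c2ccc3c(c2)OCCO3)n1-c1ccccc1`, differs from compound 2 in one place: 2,6-difluorophenyl in place of 3-methoxyphenyl on a saturated chain carbon bound to a sulfur. Going by the values given here, no measured step pairs a 2,6-difluorophenyl with a 3-methoxyphenyl, so the only guidance is the single measured step, which shows that the group on this saturated chain carbon can move the number beyond the scatter, and that compound 2 sits at a limit from which any change in the number can only be downward or unseen. Compound 3 is therefore expected to return a number near or somewhat below the limit, with the expected step of an at least 1.6-fold lower number from compound 2 to compound 3 (0.22 log units; that floor lies within the scatter) carrying wide uncertainty. The estimate for compound 3 is 60000 nM, within 20000 nM to 150000 nM.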

Compound 3, half-maximal inhibitory concentration: 84200 nM
The estimate for compound 3 lay 1.4-fold (0.15 log units) below the measured number, and the stated range covers the measured number.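

With compound 3, a second group on the saturated chain carbon bound to a sulfur gives a measured number in this assay, and 2,6-difluorophenyl in place of 2-nitrophenyl gives a 3.2-fold higher number from compound 1 to compound 3 (0.50 log units; beyond the scatter). Among the three groups shown, 2-nitrophenyl is thus the only one whose number lies lower, beyond the scatter, than both of the others, so two different replacements now lose ground against it rather than one. Against 3-methoxyphenyl, the change to 2,6-difluorophenyl gives only an at least 1.1-fold lower number from compound 2 to compound 3 (0.07 log units; that floor lies within the scatter), so no real difference between these two groups can be claimed, and compound 2 remains a limit of the assay and not a number: the limit of > 100000 nM in this assay, at which 1 of the 3 values shown sits.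

The compounds shown leave open whether a simple unsubstituted phenyl, an aminophenyl or a carboxyphenyl on this carbon would stand with 2-nitrophenyl or with the two weaker groups, and so whether the nitro group itself matters. They also leave open whether a longer chain between the sulfur and the ring, or a change elsewhere on the shared core, would move the number further in this assay.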